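This account rests on a few compounds, and the source may have more. Where it says the series, first, only, none or still open, it means among the compounds named here.

Going by the values given here, compound 2 `CC(=O)NCC(=O)N(C)c1ccc(Cl)cc1C(=O)c1ccccc1Cl` shows the lowest of the two numbers so far in a functional assay on the whole organism for antagonist activity, with Mus musculus as the target; on this read-out lower numbers stand for an effect already at smaller amounts and higher numbers for an effect only at larger amounts of compound: compound 2 gives 2.3 mg/kg, whereas compound 1 `CN(C(=O)CNC(=O)CN1CCCCC1)c1ccc(Cl)cc1C(=O)c1ccccc1Cl` gives 7.5 mg/kg. Among the compounds with values here, the single measured step is a 3.3-fold lower number from compound 1 to compound 2 (0.51 log units; beyond the scatter). Compound 3 `CN(C(=O)CNC(=O)CN)c1ccc(Cl)cc1C(=O)c1ccccc1Cl` has not yet been measured; it differs from compound 2 by amino in place of hydrogen on a saturated chain carbon bound to a carbonyl carbon. That earlier step bears on the new one only loosely, since what enters in compound 3 is amino rather than piperidin-1-yl at the same place. Because the step of a 3.3-fold lower number from compound 1 to compound 2 (0.51 log units; beyond the scatter) gave a lower number once the piperidin-1-yl group was gone, a smaller amine entering in compound 3 is expected to move the number part of the way back up, a 1.7-fold higher number from compound 2 to compound 3 (0.24 log units; within the scatter), although a change within the scatter is also plausible. Compound 3 is therefore estimated at 4 mg/kg, within 1.5 mg/kg to 10 mg/kg.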

Compound 3, dose for half-maximal effect: 0.58 mg/kg
Compound 3: middle estimate off by 6.9-fold (0.84 log units), on the high side, and the stated range ends above it.
By their numbers in this assay, from the lowest: compound 3; then compound 2; then compound 1.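

Compound 1 and compound 2 alone could be read as showing that any group on the saturated chain carbon bound to a carbonyl carbon raises the number in this assay but amino breaks that reading, giving a 4.0-fold lower number from compound 2 to compound 3 (0.60 log units; beyond the scatter) instead of a rise. The outcome at this place therefore depends on which group enters, and not simply on whether one does: amino in place of piperidin-1-yl gives a 13-fold lower number from compound 1 to compound 3 (1.11 log units; beyond the scatter) and puts these two groups on opposite sides of hydrogen. Nothing available here accounts for this difference between the groups. Going by these compounds, whether a dimethylamino group, a longer chain ending in an amine, or a carboxylic acid at this place would follow amino or piperidin-1-yl stays open. The compounds shown also share one core, and whether amino gives a similar step on a different core remains open too.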